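The compounds below may be only part of what the source reports. "The series", "measured", "known", "first", "only" and "open" are said of these compounds alone.

Compound 1 `N[C@H]1CC[C@H](Nc2c(C(=O)NCc3ccc(F)cc3)nc(Br)c3cccnc23)CC1` is the more potent of the two measured compounds here: in a functional assay on HCT-116 cells (Homo sapiens) for cytotoxicity, read by MTT assay, with a stated time of 72 h (a higher number here means a weaker inhibitor, a lower number a stronger inhibitor), compound 1 gives 4000 nM, the lowest of the two numbers. Among the measured compounds shown here, its only measured neighbour is compound 2 `N[C@H]1CC[C@H](Nc2c(C(=O)NCc3ccc(F)cc3)nc(N3CCCCC3)c3cccnc23)CC1`, which in this assay gives 8500 nM; the step of a 2.1-fold higher number from compound 1 to compound 2 (0.33 log units; beyond the scatter) involves piperidin-1-yl in place of bromo on an aromatic carbon, a different place on the shared core from the change considered next.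

Compound 3 `COC(=O)CNc1c(C(=O)NCc2ccc(F)cc2)nc(Br)c2cccnc12` differs from compound 1 at the nitrogen on the aromatic ring: (methoxycarbonyl)methyl in place of 4-aminocyclohexyl on a nitrogen on an aromatic ring. For the measured compounds named here, no measured step touches this position, so nothing in the data sets the size or direction of the change in this assay. With that absence, the expectation rests on the starting point alone, and a modest weakening is assumed with wide uncertainty. Compound 3 is therefore expected to give about 8000 nM in this assay, within 2500 nM to 25000 nM, an estimated step of a 2.0-fold higher number from compound 1 to compound 3 (0.30 log units; within the scatter).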

Compound 3, half-maximal inhibitory concentration: > 10000 nM
Compound 3: a limit, no number; the forecaster's own chance of this, stated with the estimate: 15%; middle value at least 1.2-fold (0.09 log units) away from the limit.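

The nitrogen on the aromatic ring now has its first measured step in this assay, and it is a step beyond the scatter: putting (methoxycarbonyl)methyl in place of 4-aminocyclohexyl gives an at least 2.5-fold higher number from compound 1 to compound 3 (0.39 log units; beyond the scatter). Compound 3 keeps the bromo of compound 1, so this step reflects the change at this nitrogen alone. Compound 3 is read only as a limit of the assay, not as a number, so the step sets a direction and a smallest size but no full size: the limit of > 10000 nM in this assay, at which 1 of the 3 values shown sits.

The compounds shown leave open whether the step goes with the six-membered ring or with the amine, as both leave together in this change. A plain cyclohexyl group and a short open chain ending in an amine would tell these two apart.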